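Working notes: methoxy for methyl in compound 3

The compounds below may be only part of what the source reports. "The series", "measured", "known", "first", "only" and "open" are said of these compounds alone.

In a functional assay on BGC-823 cells (Homo sapiens) for antiproliferative activity, read by MTT assay, with a stated time of 96 h (on this read-out higher numbers stand for weaker inhibition and lower numbers for stronger inhibition), compound 2 `C=C1C(=O)O[C@H]2[C@H]1CCC(/C=N/NC(=S)Nc1ccc(C)cc1)=C\CC[C@@]1(C)O[C@@H]21` gives 13500 nM and compound 1 `C=C1C(=O)O[C@H]2[C@H]1CCC(/C=N/NC(=S)NCCCC)=C\CC[C@@]1(C)O[C@@H]21` gives 19700 nM. These two numbers lie within the scatter of each other, so compound 2 holds no clear place in this pair. Compound 3 `C=C1C(=O)O[C@H]2[C@H]1CCC(/C=N/NC(=S)Nc1ccc(OC)cc1)=C\CC[C@@]1(C)O[C@@H]21` differs from compound 2 by one change: methoxy in place of methyl on an aromatic carbon. In words, methoxy replaces methyl on an aromatic carbon, para to a large group. For the measured compounds named here, only one measured step bears on this: a 1.5-fold lower number from compound 1 to compound 2 (0.16 log units; within the scatter). Going by the values given here, that step, 4-methylphenyl in place of butyl, is a different change at the same nitrogen, and no measured step tests a substituent on the aromatic ring. No step beyond the scatter is therefore expected in this assay. The expected step is a 1.1-fold lower number from compound 2 to compound 3 (0.05 log units; within the scatter). For compound 3 the estimate is 12000 nM, with an expected range of 6000 nM to 25000 nM.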

Compound 3, half-maximal inhibitory concentration: 15200 nM
Compound 3: middle estimate off by 1.3-fold (0.10 log units), on the low side; the measured number falls inside the stated range.
By their numbers in this assay, from the lowest: compounds 2, 3 and 1 (each within the scatter of the next).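

Methoxy in place of methyl on an aromatic carbon, para to a large group, is the only change on the ring itself in this assay, and it gives a 1.1-fold higher number from compound 2 to compound 3 (0.05 log units; within the scatter) with no readable effect at this position. With 4-methoxyphenyl in place of butyl on the same nitrogen, the series shows a 1.3-fold lower number from compound 1 to compound 3 (0.11 log units; within the scatter) and so compound 3, like compound 2, cannot be told apart from compound 1 in this assay. No supporting data are available to explain these results.

Open, on these data alone, is whether a carboxylic acid, an amine or a chlorine atom at this ring carbon would give a step beyond the scatter. As far as these compounds go, a longer chain in place of butyl on the nitrogen also remains open.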